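The compounds below may be only part of what the source reports. "The series", "measured", "known", "first", "only" and "open" are said of these compounds alone.

Measured compounds:
compound 1, `O=C(O)CCc1ccc(OCC2COc3cc(Br)ccc3O2)cc1F`, 67%
compound 2, `CC#CC(CC(=O)O)c1ccc(OCC2COc3ccc(Cl)cc3O2)cc1`, 104%
compound 3, `Cn1ccnc1C(CC(=O)O)c1ccc(OCC2COc3ccc(Cl)cc3O2)cc1`, 68%

In a functional assay on HEK293 cells for agonist activity at Free fatty acid receptor 1 (Homo sapiens), read by fluorescence and calcium flux, with a stated time of 10 min (a lower number here means a smaller maximal response, a higher number a larger maximal response), compound 3 stands second of the three measured numbers. Compound 1 lies within the scatter of it, while compound 2 lies beyond it, and the only step among these compounds, a number 36 percentage points lower from compound 2 to compound 3 (beyond the scatter), is what separates them. Compound 4, `O=C(O)CC(c1ccncc1)c1ccc(OCC2COc3ccc(Cl)cc3O2)cc1`, has not been measured; it differs from compound 3 in one place: pyridin-4-yl in place of 1-methyl-1H-imidazol-2-yl on a saturated chain carbon bound to an aromatic carbon and a saturated chain carbon. Among the measured compounds shown here, no measured step exchanges one aromatic ring for another at this position, so the step from compound 2 to compound 3 bears on it only as the single change seen at the same place, and it gives no direction. Compound 4 is therefore expected to move by a number 10 percentage points higher from compound 3 to compound 4 (within the scatter), a step near the scatter, with its value estimated at 78%, between 55% and 102%.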

Compound 4, largest response reached (Emax), in percent of the reference or control that the assay uses: 62%
For compound 4 the middle estimate is 16 percentage points above the measured one, within the range that was stated.
By their numbers in this assay, from the lowest: compounds 4, 1 and 3 (each within the scatter of the next); then compound 2.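

In this assay the exchange of one aromatic ring for another at this position gives a number 6 percentage points lower from compound 3 to compound 4 (within the scatter) and so does not separate the five-membered ring with two hetero atoms from the six-membered ring with one. Pyridin-4-yl in place of prop-1-yn-1-yl gives a number 42 percentage points lower from compound 2 to compound 4 (beyond the scatter) and shows that the large step away from compound 2 is not confined to 1-methyl-1H-imidazol-2-yl. No measured evidence offers an explanation for either step. Going by these compounds, whether phenyl, a ring without nitrogen, would stand with these two rings or with prop-1-yn-1-yl remains open.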